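Swapping a ring for a chain on the sulfonyl group

The compounds below may be only part of what the source reports. "The series", "measured", "known", "first", "only" and "open" are said of these compounds alone.

Among the compounds with values here, compound 2 `CCn1c(=O)c2nc(-c3ccc(S(=O)(=O)N4CCSCC4)cc3)[nH]c2n(CC)c1=O` gives 646 nM in an assay for binding affinity to adenosine receptor A1 (Rattus norvegicus), read by radioligand binding (a lower number here means a stronger inhibitor, a higher number a weaker inhibitor), the higher of the two numbers measured so far. Compound 1 `CCCn1c(=O)c2nc(-c3ccccc3N)[nH]c2n(CCC)c1=O` gives 41 nM in this assay, a lower number that lies beyond the usual scatter. Compound 3 `CCn1c(=O)c2nc(-c3ccc(S(=O)(=O)NCC(C)O)cc3)[nH]c2n(CC)c1=O` differs from compound 2 in one place: (2-hydroxypropyl)amino in place of thiomorpholin-4-yl on a sulfonyl sulfur. Within the data shown here, no measured pair shows such a change, so the expected step of a 1.4-fold lower number from compound 2 to compound 3 (0.16 log units; within the scatter) is small and within the usual scatter, leaning toward a lower number. Compound 3 is estimated at 450 nM, with a range from 150 nM to 1400 nM.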

Compound 3, half-maximal inhibitory concentration: 138 nM
Compound 3: middle estimate off by 3.3-fold (0.51 log units), on the high side; measured number below the stated range.
By their numbers in this assay, from the lowest: compound 1; then compound 3; then compound 2.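

In this assay, the place on the sulfonyl sulfur responds to the group it carries: (2-hydroxypropyl)amino in place of thiomorpholin-4-yl gives a 4.7-fold lower number from compound 2 to compound 3 (0.67 log units; beyond the scatter) as a modest change. The ring is therefore not required here, and an open chain does better in this single pair. Nothing shown explains the drop in the number.

From the compounds shown here alone, it remains open whether the ring's loss, the hydroxyl or the hydrogen on the sulfonamide nitrogen matters most. A plain propylamino chain or a morpholin-4-yl ring at this place would help separate these.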